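Epimer at the ring carbon in a triazole-free azide series

A few compounds are considered here, and "the series" means these few. Any claim that something is new, unique, unknown or untested is made for them only; others in the source may bear on it.

Measured so far in an assay on isolated protein for inhibition of alpha-mannosidase (Canavalia ensiformis), with stated times of 5 min and 20 min, tested at 1 mM; on this read-out higher numbers stand for more inhibition at the one concentration tested (going by the name of the read-out) and lower numbers for less inhibition:
compound 1, `[N-]=[N+]=NC[C@H]1NC[C@@H](O)[C@H]1O`: 43%
compound 2, `O[C@@H]1[C@H](O)CN[C@@H]1Cn1cc(-c2ccccc2)nn1`: "not active" (no number reported)
compound 3, `O[C@@H]1[C@H](O)CN[C@H]1CNC(=S)Nc1ccccc1`: "not active" (no number reported)

Among the measured compounds shown here, compound 1 is the only member of the set with a numerical result in this assay; it gives 43%. Compound 2 and compound 3 are each reported without a number and stand as inactive, so nothing can be read about how the aryl-triazole or the thiourea side arm compares with the azidomethyl arm beyond the bare fact that only compound 1 registers.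

Compound 4, `[N-]=[N+]=NC[C@@H]1NC[C@@H](O)[C@H]1O`, is the next entry. It differs from compound 1 as follows: the two compounds have the same atoms and bonds; at least one stereo element is drawn with a configuration in one of them and without one in the other: 1 of 4 stereo elements differ; a stereocentre at a saturated ring carbon is drawn R in compound 1 and S in compound 4. For the measured compounds named here, no pair of measured compounds sharing a single change is available, so no measured step guides the size of the effect. Inversion of one stereocentre on the saturated ring in an otherwise unchanged polyhydroxylated scaffold is the kind of change that can move this read-out well beyond the scatter in either direction, or leave it unchanged.

The expected step of a number 13 percentage points lower from compound 1 to compound 4 (beyond the scatter) is taken as a modest drop with wide uncertainty. Compound 4 is therefore estimated at 30%, with a range of 5% to 60%, and a real chance that it is reported only as inactive.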

Compound 4, a percentage reported as inhibition, at one concentration (the size of the read-out at that concentration, not a potency): 71%
Compound 4: middle estimate off by 41 percentage points, on the low side; the whole stated range lies below it.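

In this assay, the configuration at this saturated ring carbon carries real weight: inverting that one stereocentre, with atoms and bonds unchanged, gives a number 28 percentage points higher from compound 1 to compound 4 (beyond the scatter). Among the compounds shown here, the earlier entries showed only that the azidomethyl arm registered while the aryl-triazole and thiourea arms did not, and no two of them formed a single-place comparison, so this is the first readable step and it concerns the ring stereocentre rather than the side arm. For the azidomethyl arm, the carbon drawn S gives the higher reading, and the only structural basis available for that gain is this: the fact that one of compounds 1 and 4 is drawn with a defined configuration and the other without, at the place where they differ.

Both readings come from one concentration, so the step says nothing about how far potency differs between the two epimers, and it is not known whether the same inversion would have a similar effect on other arms. An aminomethyl or hydroxymethyl arm in place of the azidomethyl arm, carried on each configuration of this carbon, would show whether the gain belongs to the stereocentre alone or depends on the azide.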